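Aryl swap on the chain: compound 2 to compound 4

The compounds below may be only part of what the source reports. "The series", "measured", "known", "first", "only" and "open" are said of these compounds alone.

For the measured compounds named here, compound 2 `COc1ccc(/C=C/C(=O)c2ccccc2NC(=O)NS(=O)(=O)c2ccc(C)cc2)c(OC)c1` gives 16 ug/mL in an ADME assay on the whole organism for cytotoxicity, with Artemia salina as the target, with a stated time of 24 h (a higher number here means that more compound is needed for the effect, a lower number that less compound is needed), the lowest of the three numbers so far, though its steps to both other compounds lie within the scatter. Compound 3 `Cc1ccc(S(=O)(=O)NC(=O)Nc2ccccc2C(=O)/C=C/c2ccc(O)cc2)cc1` gives 24.3 ug/mL and compound 1 `Cc1ccc(S(=O)(=O)NC(=O)Nc2ccccc2C(=O)/C=C/c2ccccc2)cc1` gives 25 ug/mL. Compound 4 `Cc1ccc(S(=O)(=O)NC(=O)Nc2ccccc2C(=O)/C=C/c2cccc(Br)c2)cc1` is not yet measured; it differs from compound 2 thus: 3-bromophenyl in place of 2,4-dimethoxyphenyl on a double-bonded chain carbon bound to a double-bonded chain carbon. Two measured steps alter the group at this place and therefore bear on the change: a 1.6-fold lower number from compound 1 to compound 2 (0.19 log units; within the scatter) and a 1.5-fold higher number from compound 2 to compound 3 (0.18 log units; within the scatter). Neither moved the number beyond the scatter, so no step beyond the scatter is expected here either; the step expected is a 1.4-fold higher number from compound 2 to compound 4 (0.14 log units; within the scatter). For compound 4 the estimate in this assay is 22 ug/mL, with a range from 11 ug/mL to 45 ug/mL.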

Compound 4, concentration for half-maximal effect: 4.02 ug/mL
Compound 4: the middle estimate sits 5.5-fold (0.74 log units) above what was measured; the whole stated range lies above it.
By their numbers in this assay, from the lowest: compound 4; then compounds 2, 3 and 1 (each within the scatter of the next).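

In (this assay), phenyl, 2,4-dimethoxyphenyl and 4-hydroxyphenyl stay within the scatter of one another at this place, whereas 3-bromophenyl gives a clearly lower number: (a 4.0-fold lower number from compound 2 to compound 4 (0.60 log units; beyond the scatter)), (a 6.0-fold lower number from compound 3 to compound 4 (0.78 log units; beyond the scatter)) and (a 6.2-fold lower number from compound 1 to compound 4 (0.79 log units; beyond the scatter)). The last of these is a single change, bromo in place of hydrogen on an aromatic carbon, so one substituent suffices here to move the number beyond the scatter. No measured evidence bears on the reason for this result.

From the compounds shown here alone, whether the lower number is particular to bromo remains open. A 3-chlorophenyl or 3-methylphenyl group at this place would test that.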